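Cytotoxicity notes on the amide side-chain series

This account rests on a few compounds, and the source may have more. Where it says the series, first, only, none or still open, it means among the compounds named here.

Measured so far:
- compound 1 `CCN(CC)CC[n+]1c(SCC(=O)NCCN)[nH]c2c(C)nc(N(CC)CC)nc21`: in an ADME assay on CEM174 cells (Homo sapiens) for cytotoxicity (on this read-out lower numbers stand for higher toxicity in this test and higher numbers for lower toxicity in this test), compound 1 gives 52.2 uM.
- compound 2 `CCN(CC)CC[n+]1c(SCC(=O)NCCCN)[nH]c2c(C)nc(N(CC)CC)nc21`: in this assay compound 2 gives > 100 uM, which is a limit of the assay and not a number.

Compound 2 therefore stands at the upper edge of what this assay reports, with no number of its own. For the measured compounds named here, the one measured step is an at least 1.9-fold higher number from compound 1 to compound 2 (0.28 log units; that floor lies within the scatter); it rests on (the limit of > 100 uM in this assay, at which 1 of the 2 values shown sits), so its true size is open upward.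

Compound 3 `CCN(CC)CC[n+]1c(SCC(=O)NCCNC(=N)N)[nH]c2c(C)nc(N(CC)CC)nc21` is not yet measured. It differs from compound 2 by a group of 4 heavy atoms (1 carbon, 3 nitrogen; no ring) in place of a group of 2 heavy atoms (1 carbon, 1 nitrogen; no ring), on a saturated chain carbon, two bonds along the chain from an amide-type nitrogen. Both the group that leaves and the group that enters sit on the same saturated chain carbon, two bonds along the chain from an amide-type nitrogen. Going by the values given here, no measured step covers this exchange; the only step available, from the amino to the aminomethyl chain, moved the number up to the limit.

The expectation for compound 3 is a step of a number no higher from compound 2 to compound 3 (the limit leaves the size open), that is, no movement beyond the scatter from the limit where compound 2 sits. Compound 3 is estimated at 100 uM, with a range from 40 uM to 250 uM, and a limit readout is thought more likely than a number.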

Compound 3, half-maximal toxic concentration: > 100 uM
Compound 3: a limit, no number; the forecaster's own chance of this, stated with the estimate: 65%; the middle value sits exactly at the limit.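

In this assay compound 3 gives > 100 uM, which is a limit of the assay and not a number. For the compounds shown here, the group of 4 heavy atoms on a saturated chain carbon, two bonds along the chain from an amide-type nitrogen, thus brings no measurable number back into this test, as the aminomethyl group of compound 2 did not either, and the one readable new step is an at least 1.9-fold higher number from compound 1 to compound 3 (0.28 log units; that floor lies within the scatter), which gives only a floor. The step between compound 2 and compound 3 cannot be read, and the comparison now stops at the edge of the assay: the limit of > 100 uM in this assay, at which 2 of the 3 values shown sit.

As far as these compounds go, how far compound 2 and compound 3 each lie past the limit, and whether they differ at all, stays open. Also open, from the compounds shown here alone, is whether a longer chain carrying an amine, or a carboxylic acid on the same saturated chain carbon, would give a number inside the range of this test.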